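This account rests on a few compounds, and the source may have more. Where it says the series, first, only, none or still open, it means among the compounds named here.

Compound 1 `C[C@@H](CF)OC(=O)N1CCC(O[C@H]2CC[C@H](Oc3cnc(S(C)(=O)=O)cn3)CC2)CC1`: in a functional assay on isolated protein for agonist activity at Glucose-dependent insulinotropic receptor (Homo sapiens), read by HTRF and cAMP accumulation (a lower number here means a smaller maximal response, a higher number a larger maximal response), compound 1 gives 105%.
Compound 2 `CS(=O)(=O)c1cnc(O[C@H]2CC[C@H](OC3CCN(C(=O)OC4CCOC4)CC3)CC2)cn1`: compound 2 gives 105%.
Compound 3 `CS(=O)(=O)c1cnc(O[C@H]2CC[C@H](OC3CCN(C(=O)Oc4ccccc4)CC3)CC2)cn1`: compound 3 gives 116%.

Compound 3 stands highest of the three in this assay, with both others lower beyond the scatter: a number 11 percentage points higher from compound 1 to compound 3 (beyond the scatter) and a number 11 percentage points higher from compound 2 to compound 3 (beyond the scatter), whereas no change at the digits printed from compound 1 to compound 2 (within the scatter). Compound 4 `CS(=O)(=O)c1cnc(O[C@H]2CC[C@H](OC3CCN(C(=O)C4(C(F)(F)F)CC4)CC3)CC2)cn1` differs from compound 3 in one place: 1-(trifluoromethyl)cyclopropyl in place of phenoxy on a carbonyl carbon. Going by the values given here, none of the measured steps touches this position; all three exchange a different group, and none shifted the maximal response by more than a modest amount, so no measured step bears directly on the change. Compound 4 is therefore expected to stay close to the measured three, with a modest fall from compound 3 as the likelier outcome: a number 11 percentage points lower from compound 3 to compound 4 (beyond the scatter). Compound 4 is estimated at 105%, within 90% to 120%.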

Compound 4, largest response reached (Emax), in percent of the reference or control that the assay uses: 107%
Compound 4: the middle estimate sits 2 percentage points below what was measured; low and high end bracket the measured number.
By their numbers in this assay, from the lowest: compounds 1, 2, 4 and 3 (each within the scatter of the next, the first and the last beyond it).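

In this assay, exchanging phenoxy for 1-(trifluoromethyl)cyclopropyl on this carbonyl carbon gives (a number 9 percentage points lower from compound 3 to compound 4 (within the scatter)), so the maximal response holds at this position with a group that has no oxygen and no aromatic ring. Compared with the two non-aromatic groups, the picture is the same: a number 2 percentage points higher from compound 2 to compound 4 (within the scatter) and a number 2 percentage points higher from compound 1 to compound 4 (within the scatter) are both steps inside the scatter. No evidence is available that explains these numbers. From the compounds shown here alone, what stays open is whether an amine or a carboxylic acid on this carbonyl carbon, or a longer chain in place of the cyclopropyl, would keep the response.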